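From acetamido to anilino on a shared core

The source may hold more compounds than are shown below. What is called first, only, known or untested is meant among the compounds shown, and "the series" means these compounds.

- compound 1 `Cc1c(C)c2c(c(C)c1N)CC(C)(CN1CCC(c3ccccc3)CC1)O2` gives 10.4 mg/kg
- compound 2 `Cc1c(C)c2c(c(C)c1N)CC(C)(CCc1ccc(F)cc1)O2` gives 11.5 mg/kg
- compound 3 `CC(=O)Nc1c(C)c(C)c2c(c1C)CC(C)(C)O2` gives > 100 mg/kg
- compound 4 `Cc1c(C)c2c(c(C)c1Nc1ccccc1)CC(C)(C)O2` is not yet measured

All of these values come from a functional assay on the whole organism with Mus musculus as the target; on this read-out higher numbers stand for an effect only at larger amounts of compound and lower numbers for an effect already at smaller amounts. For compound 3 the entry (> 100 mg/kg) is a limit and not a number.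

Compound 4 has phenyl in place of acetyl on a nitrogen on an aromatic ring, which turns acetamido into anilino.

Compound 1 (10.4 mg/kg) and compound 2 (11.5 mg/kg) carry no acetyl on that nitrogen, and both give numbers. On that ground, a clear step toward smaller doses is expected in this assay, although its size is uncertain. The expected change is an at least 3.3-fold lower number from compound 3 to compound 4 (0.52 log units; beyond the scatter). For compound 4 the estimated value is 30 mg/kg, with an expected range from 8 mg/kg to 100 mg/kg.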

Compound 4, dose for 50% inhibition: > 50 mg/kg
Compound 4 ended at the assay's limit; the forecaster's own chance of this, stated with the estimate: 15%; middle value at least 1.6-fold (0.22 log units) away from the limit.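

For the compounds shown here, compound 3 and compound 4 both end at limits of this assay and not at numbers, so no step between them can be read. The compounds shown leave open whether phenyl in place of acetyl on that nitrogen changes the dose at all.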